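Swapping a hexyl chain for phenyl on a weakly cytotoxic quinone

The source may report more compounds than this note shows. Statements on the series, on what has been measured and on what is new or still open speak of the compounds shown alone.

Measured compounds:
Compound 1, `COC(C)CO[C@H](CC=C(C)C)C1=CC(=O)c2c(O)ccc(O)c2C1=O`, gives 53400 nM in a functional assay on HeLa cells (Homo sapiens) for cytotoxicity, read by MTT assay; on this read-out higher numbers stand for weaker inhibition and lower numbers for stronger inhibition.
Compound 2, `COCCO[C@H](CC=C(C)C)C1=CC(=O)c2c(O)ccc(O)c2C1=O`, gives 62400 nM in this assay.
Compound 3, `CCCCCCC(C)(O)CC(=O)O[C@H](CC=C(C)C)C1=CC(=O)c2c(O)ccc(O)c2C1=O`, gives > 100000 nM in this assay.

The three compounds share one core and differ in the group attached through oxygen to the saturated carbon bearing the branched alkenyl chain. Compound 1 and compound 2 are related by a single small change, a 1.2-fold higher number from compound 1 to compound 2 (0.07 log units; within the scatter), so the two stand together. For compound 3 the read-out is not a number but a limit of the assay, and it is the only one of the three at that limit (the limit of > 100000 nM in this assay, at which 1 of the 3 values shown sits). Compound 3 therefore stands at the weak end of what is shown.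

Compound 4, `CC(C)=CC[C@@H](OC(=O)CC(C)(O)c1ccccc1)C1=CC(=O)c2c(O)ccc(O)c2C1=O`, has not been measured in this assay. Its change from compound 3 is phenyl in place of hexyl on a saturated chain carbon bound to an oxygen on a saturated carbon and two saturated chain carbons. Among the measured compounds shown here, no measured step touches this position, and the one measured step concerns a different part of the side chain, so it gives no direct guide; the only anchor is that compound 3 sits at the limit. Compound 4 is therefore expected to remain weak, with a step that the limit leaves unreadable from compound 3 to compound 4 that is little more than a guess. The estimated value for compound 4 is 120000 nM, expected between 40000 nM and 400000 nM.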

Compound 4, half-maximal inhibitory concentration: 85700 nM
Compound 4: the middle estimate sits 1.4-fold (0.15 log units) above what was measured; the range from low to high includes it.
By their numbers in this assay, from the lowest: compounds 1, 2 and 4 (each within the scatter of the next). At a limit, above all of these: compound 3.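

In this assay compound 4 gives 85700 nM, so this position takes a phenyl, one six-membered aromatic ring of carbon only, in place of the open hexyl chain of the same heavy-atom count, and the read-out is a number rather than a limit. For compound 3 the value > 100000 nM is a limit of the assay. The change therefore reads as an at least 1.1-fold lower number from compound 3 to compound 4 (0.06 log units; that floor lies within the scatter), and this is only a floor on the true size of the step because one of its two ends is a limit: the limit of > 100000 nM in this assay, at which 1 of the 4 values shown sits.

On these data alone, the true size of the step stays open, and the floor alone does not establish any real gain from the swap. Also open, as far as these compounds go, is how the read-out would respond at this same position to a methyl, to a longer chain such as octyl, or to a phenyl carrying an amine or a carboxylic acid.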